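This account rests on a few compounds, and the source may have more. Where it says the series, first, only, none or still open, it means among the compounds named here.

Of the compounds shown here, three built on a shared core have been measured in a functional assay on MCF7 cells (Homo sapiens) for inhibition, read by MTT assay, with a stated time of 48 h, tested at 10 uM; on this read-out lower numbers stand for less inhibition of growth and higher numbers for more inhibition of growth at the one concentration tested. Compound 1 `Cc1cc(=O)c2c(O)c(CN3CCCC3)c(O)c([C@H]3CCN(C)C[C@H]3O)c2o1` gives 12%. Going by the values given here, compound 2 `Cc1cc(=O)c2c(O)c(CN(C)CC(=O)O)c(O)c([C@H]3CCN(C)C[C@H]3O)c2o1` gives 27%, and the single measured one-place step, a number 15 percentage points higher from compound 1 to compound 2 (beyond the scatter), concerns the amine on a saturated chain carbon bound to an aromatic carbon. Compound 3 `Cc1oc2c([C@H]3CCN(C)C[C@H]3O)c(O)cc(O)c2c(=O)c1C(O)c1ccccc1Br` gives 21%, a number that differs from those of compound 2 and of compound 1 only within the usual scatter of repeated measurements, so none of the three can be set apart from the others with confidence.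

Compound 4 `Cc1oc2c([C@H]3CCN(C)C[C@H]3O)c(O)cc(O)c2c(=O)c1C(O)c1ccc(F)cc1` differs from compound 3 in one place: 4-fluorophenyl in place of 2-bromophenyl on a saturated chain carbon bound to an aromatic carbon and an oxygen on a saturated carbon. Among the compounds with values here, no measured step concerns this group: the one step known, from compound 1 to compound 2, changes a different group and was itself only modest, so it offers no guide to direction or size here. With nothing pointing to a change, the expected step is no change at the digits printed from compound 3 to compound 4 (within the scatter) in this assay, meaning none beyond the scatter. Compound 4 is therefore estimated at 21%, with a range from 8% to 36%.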

Compound 4, percent growth inhibition at one concentration: 9%
Compound 4: the middle estimate sits 12 percentage points above what was measured, within the range that was stated.
By their numbers in this assay, from the lowest: compounds 4, 1, 3 and 2 (each within the scatter of the next, the first and the last beyond it).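

In this assay, the aryl group on this saturated chain carbon, bound to an aromatic carbon and an oxygen on a saturated carbon, affects the result: the step is a number 12 percentage points lower from compound 3 to compound 4 (beyond the scatter). The two groups have the same count of heavy atoms, the same six-membered aromatic carbon ring and the same count of hydrogen-bond donors and acceptors, so the identity and place of the halogen are all that differ between them. No measurement shown gives a reason for this step.

Bromine gives way to fluorine and the halogen's place changes in the same step, so the compounds shown cannot separate these two changes. A 4-bromophenyl or a 2-fluorophenyl group would each alter only one of them, while a plain phenyl group would show the outcome with no halogen at all.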